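The compounds below may be only part of what the source reports. "The series", "measured", "known", "first", "only" and "open" are said of these compounds alone.

Three compounds share one core and differ only in what hangs from the amine at the far end. Compound 1 `O=S(=O)(NCC1CCN(CCCc2c[nH]c3ccc(-n4cnnc4)cc23)CC1)c1ccccc1` gives 12 nM in an assay on CHO cells for agonist activity at 5-hydroxytryptamine receptor 1D (Homo sapiens), read by GTPgammaS binding; on this read-out higher numbers stand for an effect only at larger amounts of compound and lower numbers for an effect already at smaller amounts. Compound 2 `c1ccc(CNCC2CCN(CCCc3c[nH]c4ccc(-n5cnnc5)cc34)CC2)cc1` gives 5.6 nM in this assay, and compound 3 `O[C@@H]1Cc2ccccc2[C@H]1NC1CCN(CCCc2c[nH]c3ccc(-n4cnnc4)cc23)CC1` gives 13 nM. Among these three numbers compound 3 has the highest; in this assay there is a 1.1-fold higher number from compound 1 to compound 3 (0.03 log units; within the scatter), while a 2.3-fold higher number from compound 2 to compound 3 (0.37 log units; beyond the scatter).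

Compound 4 `c1ccc2c(c1)CCC2NC1CCN(CCCc2c[nH]c3ccc(-n4cnnc4)cc23)CC1` is the next compound; it differs from compound 3 in one place: 2,3-dihydro-1H-inden-1-yl in place of 2-hydroxy-2,3-dihydro-1H-inden-1-yl on an amine nitrogen. The leaving group carries one hydrogen-bond donor and one hydrogen-bond acceptor, the entering group none. Among the measured compounds shown here, no measured step removes this group alone; the steps seen so far, a 2.1-fold lower number from compound 1 to compound 2 (0.33 log units; beyond the scatter) and a 2.3-fold higher number from compound 2 to compound 3 (0.37 log units; beyond the scatter), exchange the whole amine substituent and move the number only modestly. A smaller change is therefore expected to give a step of about a 1.2-fold higher number from compound 3 to compound 4 (0.06 log units; within the scatter), within the scatter. For compound 4 the expected value in this assay is 15 nM, with a range from 6 nM to 40 nM.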

Compound 4, half-maximal effective concentration: 25 nM
Beside the measured number, compound 4's estimate is 1.7-fold (0.22 log units) below it; the range from low to high includes it.
By their numbers in this assay, from the lowest: compound 2; then compounds 1, 3 and 4 (each within the scatter of the next, the first and the last beyond it).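

Exchanging 2-hydroxy-2,3-dihydro-1H-inden-1-yl for 2,3-dihydro-1H-inden-1-yl on the amine nitrogen gives a step that stays within the scatter in this assay (a 1.9-fold higher number from compound 3 to compound 4 (0.28 log units; within the scatter)), so the hydrogen-bond donor and acceptor of the leaving group are not shown to matter in this assay. Without the hydroxy group, the two wider comparisons both lie beyond the scatter (a 2.1-fold higher number from compound 1 to compound 4 (0.32 log units; beyond the scatter); a 4.5-fold higher number from compound 2 to compound 4 (0.65 log units; beyond the scatter)), and the second is the larger, though both also exchange the whole amine substituent. No measurement here explains these steps.

The leaving group has defined stereocentres, so the effect of its hydroxy group cannot be separated from that of its stereochemistry. As far as these compounds go, how a methoxy or an amino group would behave on that ring remains open.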